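A few compounds are considered here, and "the series" means these few. Any claim that something is new, unique, unknown or untested is made for them only; others in the source may bear on it.

- Compound 1 `Cn1cncc1CN1CC(N(CC2CCN(C(=O)c3ccc(Cl)cc3)CC2)S(=O)(=O)c2ccccn2)Cc2cc(C#N)ccc21`: 0.5 10^-6 cm/s
- Compound 2 `Cn1cncc1CN1CC(N(CC2CCN(C(=O)C3CCCC3)CC2)S(=O)(=O)c2ccccn2)Cc2cc(C#N)ccc21`: 0.5 10^-6 cm/s
- Compound 3 `CCC(=O)N1CCC(CN(C2Cc3cc(C#N)ccc3N(Cc3cncn3C)C2)S(=O)(=O)c2ccccn2)CC1`: 0.5 10^-6 cm/s

In an ADME assay on Caco-2 cells (Homo sapiens) for permeability, in the apical to basolateral direction (a lower number here means that the compound crosses the layer more slowly, a higher number that the compound crosses the layer faster), compound 1 stands level with compound 2 and compound 3, as all three give the same reading. Compound 4 `CC(C)S(=O)(=O)N1CCC(CN(C2Cc3cc(C#N)ccc3N(Cc3cncn3C)C2)S(=O)(=O)c2ccccn2)CC1` has yet to be measured. Its structure departs from that of compound 1 in one place: isopropylsulfonyl in place of (4-chlorophenyl)carbonyl on an amine nitrogen in a ring. This puts isopropylsulfonyl in place of (4-chlorophenyl)carbonyl on an amine nitrogen in a ring.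

Within the data shown here, three measured steps bear on this change, and each swaps the group on a carbonyl carbon: no change at the digits printed from compound 1 to compound 2 (within the scatter), no change at the digits printed from compound 1 to compound 3 (within the scatter) and no change at the digits printed from compound 2 to compound 3 (within the scatter). None goes beyond the scatter. Even so, none of them removes the carbonyl, so the data offer no direct precedent for a sulfonyl group at this nitrogen. On the evidence of these steps, no change beyond the scatter is expected, and no direction can be favoured. The expected step is no change at the digits printed from compound 1 to compound 4 (within the scatter). For compound 4 the estimated value is 0.5 10^-6 cm/s, within an expected range of 0.25 10^-6 cm/s to 1 10^-6 cm/s.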

Compound 4, apparent permeability: 0.1 10^-6 cm/s
Compound 4: middle estimate off by 5.0-fold (0.70 log units), on the high side; measured number outside the range, below it.
By their numbers in this assay, from the lowest: compound 4; then compounds 1, 2 and 3 (each within the scatter of the next).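

At the amine nitrogen in the six-membered ring, the three carbonyl groups gave no separation in this assay, but isopropylsulfonyl does, and it reads lower against each of them (by a 5.0-fold lower number from compound 1 to compound 4 (0.70 log units; beyond the scatter); by a 5.0-fold lower number from compound 2 to compound 4 (0.70 log units; beyond the scatter); and by a 5.0-fold lower number from compound 3 to compound 4 (0.70 log units; beyond the scatter)). This position is therefore not indifferent to every change, even though aryl, cycloalkyl and ethyl groups on the carbonyl carbon left the reading level. As compounds 1, 2 and 3 stand level, the size of the step does not depend on which of them it starts from.

From the compounds shown here alone, compound 4 changes both the link and the group it carries, so it remains open whether the sulfonyl or the isopropyl sets the step. A phenylsulfonyl or an isobutyryl group at this nitrogen would separate the two. Nothing shown here gives a measured explanation for the step.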